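Isomeric ester change at a potent inhibitor

The source may hold more compounds than are shown below. What is called first, only, known or untested is meant among the compounds shown, and "the series" means these compounds.

Compound 1 `NCc1ccc(C(=O)Nc2ccncc2)cc1-c1cccc(C(=O)OCc2ccccc2)c1`: 45 nM
Compound 2 `NCc1ccc(C(=O)Nc2ccncc2F)cc1-c1cccc(C(=O)OCC2CCCO2)c1`: 2.5 nM

Both numbers come from an assay on isolated protein for inhibition of Rho-associated protein kinase 2 (Homo sapiens), read by radiometric assay; on this read-out lower numbers stand for stronger inhibition and higher numbers for weaker inhibition. Compound 2 holds the lower of the two values, and its gap to compound 1 lies beyond the scatter.

Compound 3 `NCc1ccc(C(=O)Nc2ccncc2F)cc1-c1cccc(C(=O)OC2CCCOC2)c1` differs from compound 2 by oxan-3-yl in place of (oxolan-2-yl)methyl on an oxygen next to a carbonyl group. For the measured compounds named here, no measured pair shows this kind of change, so nothing in the data sets its size. Compound 3 is expected to stay close to compound 2, with a 1.6-fold higher number from compound 2 to compound 3 (0.20 log units; within the scatter) expected not to pass beyond the scatter. The estimate for compound 3 is 4 nM, with a range from 1.5 nM to 12 nM.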

Compound 3, half-maximal inhibitory concentration: 8.7 nM
The estimate for compound 3 lay 2.2-fold (0.34 log units) below the measured number; low and high end bracket the measured number.
By their numbers in this assay, from the lowest: compound 2; then compound 3; then compound 1.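

In this assay, the position on an oxygen next to a carbonyl group proves sensitive to how the same atoms are joined: oxan-3-yl in place of (oxolan-2-yl)methyl gives a 3.5-fold higher number from compound 2 to compound 3 (0.54 log units; beyond the scatter), a modest step. For the compounds shown here, this is the first comparison here that differs in this one place, and no supporting measurement bears on the result. The compounds shown leave open whether oxan-4-yl, or a longer chain ending in an amine, would keep the number of compound 2 or move it further.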